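The source may hold more compounds than are shown below. What is called first, only, known or untested is meant among the compounds shown, and "the series" means these compounds.

Compound 2 `COc1cc(-c2nnc(SCc3ccc(F)cc3F)o2)ccc1O` gives 9690 nM in a functional assay on cells (T-cell, Mus musculus, strain BALB/c) for inhibition, read by MTT assay, with stated times of 24 h and 72 h (a lower number here means a stronger inhibitor, a higher number a weaker inhibitor), the lower of the two numbers measured; compound 1 `COc1cc(-c2nnc(SCc3cccc(Br)c3)o2)ccc1O` gives 48100 nM. Within the data shown here, the one measured step, a 5.0-fold lower number from compound 1 to compound 2 (0.70 log units; beyond the scatter), concerns a different position and does not bear on the change now considered. Compound 3 `COc1cc(-c2nnc(SCc3ccc(F)cc3F)o2)ccc1OCc1ccc(F)cc1F` differs from compound 2 by 2,4-difluorobenzyl in place of hydrogen on an oxygen on an aromatic ring. Among the measured compounds shown here, no measured step touches this oxygen, so no direction can be drawn from the data, and the expected step is a 1.2-fold lower number from compound 2 to compound 3 (0.08 log units; within the scatter), within the scatter. Compound 3 is therefore estimated at 8000 nM, in a range from 2000 nM to 30000 nM.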

Compound 3, half-maximal inhibitory concentration: 12900 nM
The estimate for compound 3 lay 1.6-fold (0.21 log units) below the measured number; measured number inside the range.
By their numbers in this assay, from the lowest: compounds 2 and 3 (each within the scatter of the next); then compound 1.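

In this assay the replacement of hydroxy by (2,4-difluorobenzyl)oxy is a 1.3-fold higher number from compound 2 to compound 3 (0.12 log units; within the scatter) and shows neither gain nor loss. This oxygen on an aromatic ring therefore carries a group of 9 heavy atoms, with its one six-membered aromatic ring, while the number stays within the scatter of the hydroxy compound, so for this pair the hydrogen on the oxygen is not needed for the reading. No evidence at hand accounts for this result. Still open, on these data alone, is how a small methyl group on this oxygen would read, and whether a chain ending in an amine or a carboxylic acid would fit the same pattern.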